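The source may hold more compounds than are shown below. What is called first, only, known or untested is meant among the compounds shown, and "the series" means these compounds.

Three compounds share one core and differ only in the group carried on a single aromatic carbon. Compound 1 `O=c1c(-c2ccc([N+](=O)[O-])cc2)nc2ccccc2n1Cc1ccccc1` carries a 4-nitrophenyl group there; in an assay on cells for activation of Cystic fibrosis transmembrane conductance regulator (Homo sapiens), read by fluorescence, with a stated time of 10 min (on this read-out lower numbers stand for an effect already at smaller amounts and higher numbers for an effect only at larger amounts of compound), compound 1 gives 1000 nM. Compound 2 `O=c1c(-c2ccc(C(F)(F)F)cc2)nc2ccccc2n1Cc1ccccc1`, with trifluoromethyl in place of nitro on an aromatic carbon, gives 1000 nM in this assay, so that no change at the digits printed from compound 1 to compound 2 (within the scatter). Compound 3 `O=c1c(-c2ccc(F)c([N+](=O)[O-])c2)nc2ccccc2n1Cc1ccccc1` differs from compound 1 at two places; in this assay compound 3 gives 690 nM. Compound 1 thus gives the same number as compound 2 at the digits shown, and the number for compound 3 lies within the scatter of both, so the three cannot be told apart.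

Compound 4 `O=c1c(-c2ccc3nonc3c2)nc2ccccc2n1Cc1ccccc1` has not been measured. From compound 1 to compound 4 the change is a group of 9 heavy atoms (6 carbon, 2 nitrogen, 1 oxygen; one five-membered aromatic ring with 3 hetero atoms, one six-membered aromatic ring of carbon only) in place of a group of 9 heavy atoms (6 carbon, 1 nitrogen, 2 oxygen; one six-membered aromatic ring of carbon only), on an aromatic carbon. Among the compounds with values here, one measured step bears on a swap of this kind: a different group on the same aromatic carbon left the number unchanged, no change at the digits printed from compound 1 to compound 2 (within the scatter). Compound 1 and compound 3 likewise show similar values. Since every change seen so far at this position has stayed within the scatter, the expected step from compound 1 to compound 4 is a 1.3-fold lower number from compound 1 to compound 4 (0.10 log units; within the scatter), nothing beyond the scatter. Compound 4 is therefore estimated at 800 nM, within a range from 300 nM to 2500 nM.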

Compound 4, half-maximal effective concentration: 18 nM
Estimate against measurement, compound 4: 44-fold (1.65 log units) above; measured number outside the range, below it.
By their numbers in this assay, from the lowest: compound 4; then compounds 3, 1 and 2 (each within the scatter of the next).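

The result shows that this position is not indifferent to what it carries. Within the data shown here, the one earlier single-place step here, no change at the digits printed from compound 1 to compound 2 (within the scatter), suggested that little depended on the group, yet in this assay replacing the 4-nitrophenyl group with the fused group gives a 56-fold lower number from compound 1 to compound 4 (1.74 log units; beyond the scatter), a large step. Both groups hold 9 heavy atoms, so that count does not separate them, whereas the incoming group adds a five-membered aromatic ring with 3 hetero atoms and has 3 hydrogen-bond acceptors rather than 2, but nothing available here explains why the number falls so far.

With only one fused group shown, it remains open whether the drop depends on the whole two-ring group or on particular atoms of its five-membered ring. From the compounds shown here alone, it is also open whether a different fused ring, or an amine or a carboxylic acid on the six-membered carbon ring, would give a number close to that of compound 4 or one closer to the numbers of compound 1 and compound 2.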